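Chloro for bromo on the ring of compound 3

A few compounds are considered here, and "the series" means these few. Any claim that something is new, unique, unknown or untested is made for them only; others in the source may bear on it.

Measured so far in a functional assay on HCT-116 cells (Homo sapiens) for antiproliferative activity, read by MTT assay, with a stated time of 72 h; a higher number here means a weaker inhibitor, a lower number a stronger inhibitor:
- compound 1 `COc1cc(CCc2ccc(Cl)c(Cl)c2)cc(OC)c1O` at 1860 nM
- compound 2 `COc1cc(CCc2ccc(F)cc2)cc(OC)c1O` at 1190 nM
- compound 3 `COc1cc(CCc2ccc(Br)cc2)cc(OC)c1O` at 15900 nM

Compound 3 has the highest number of the three, beyond the scatter from both of the others. Compound 4 `COc1cc(CCc2ccc(Cl)cc2)cc(OC)c1O` carries chloro in place of bromo on an aromatic carbon, para to a large group (chloro in place of bromo on an aromatic carbon). Within the data shown here, the one measured step bearing on this is a 13-fold higher number from compound 2 to compound 3 (1.13 log units; beyond the scatter) with bromo in place of fluoro on an aromatic carbon, a large step beyond the scatter. Among the measured compounds shown here, compound 1, the only measured compound bearing chloro, has two such groups, and its value of 1860 nM lies within the scatter of compound 2 at 1190 nM in the same assay. For the measured compounds named here, a clearly lower number is therefore expected in this assay for the swap, probably a somewhat smaller step than the measured one, although no measured compound carries a single chloro. The estimate means a 5.3-fold lower number from compound 3 to compound 4 (0.72 log units; beyond the scatter) as the expected step. Compound 4 is estimated at 3000 nM with 1000 nM to 11000 nM as its expected range.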

Compound 4, half-maximal inhibitory concentration: 330 nM
For compound 4 the middle estimate is 9.1-fold (0.96 log units) above the measured one; measured number outside the range, below it.
By their numbers in this assay, from the lowest: compound 4; then compounds 2 and 1 (each within the scatter of the next); then compound 3.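

In this assay the identity of the single halogen on this ring carbon matters greatly: chloro in place of bromo gives a 48-fold lower number from compound 3 to compound 4 (1.68 log units; beyond the scatter) and chloro in place of fluoro gives a 3.6-fold lower number from compound 2 to compound 4 (0.56 log units; beyond the scatter) so compound 4 is the strongest of the four, and the numbers do not run steadily from fluoro through chloro to bromo. The second chloro of compound 1 brings no gain, since hydrogen in its place gives a 5.6-fold lower number from compound 1 to compound 4 (0.75 log units; beyond the scatter) and the single chloro is the better form in this small set. Nothing at hand explains the sharp difference between chloro and bromo at this position.

Open, going by these compounds, is whether this sensitivity extends beyond halogens, for instance to a nitrile or an amine on the same carbon. Also open, on these data alone, is whether the order of chloro, fluoro and bromo holds in other cell lines.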